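Swapping a Thiophene for a Methylphenyl Ether Group

This account rests on a few compounds, and the source may have more. Where it says the series, first, only, none or still open, it means among the compounds named here.

Compound 3 `O=C1N=C(O)S/C1=C\c1ccc(OCc2ccsc2)cc1` has been tested in an assay for inhibition of 15-hydroxyprostaglandin dehydrogenase [NAD(+)] (Homo sapiens), read by fluorescence and spectrophotometry (on this read-out higher numbers stand for weaker inhibition and lower numbers for stronger inhibition), where compound 3 gives 429 nM. Among the measured compounds shown here, that number stands second highest of the three measured so far, between compound 2 `O=C1N=C(O)S/C1=C\c1ccc(OCc2cccs2)cc1`, which gives 287 nM in this assay, and compound 1 `O=C1N=C(O)S/C1=C\c1ccc(OCCc2ccccn2)cc1`, which gives 660 nM. The step of a 1.5-fold higher number from compound 2 to compound 3 (0.17 log units; within the scatter) and the step of a 1.5-fold lower number from compound 1 to compound 3 (0.19 log units; within the scatter) both stay within the scatter, whereas the step of a 2.3-fold lower number from compound 1 to compound 2 (0.36 log units; beyond the scatter) is a modest one beyond it. Compound 4 `Cc1ccc(COc2ccc(/C=C3\SC(O)=NC3=O)cc2)cc1` differs from compound 3 in one place: 4-methylphenyl in place of thiophen-3-yl on a saturated chain carbon bound to an oxygen on an aromatic ring. For the measured compounds named here, no measured step bears directly on this change; the three measured steps only show that exchanging one small aromatic group for another at the saturated chain carbon bound to the oxygen on the aromatic ring has moved the number by no more than a modest amount. Compound 4 is therefore expected to stay close to compound 3, with an expected step of a 1.2-fold lower number from compound 3 to compound 4 (0.09 log units; within the scatter). The estimate for compound 4 in this assay is 350 nM, within a range from 150 nM to 900 nM.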

Compound 4, half-maximal inhibitory concentration: 232 nM
Compound 4: the middle estimate sits 1.5-fold (0.18 log units) above what was measured; the measured number falls inside the stated range.
By their numbers in this assay, from the lowest: compounds 4, 2, 3 and 1 (each within the scatter of the next, the first and the last beyond it).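

In this assay, 4-methylphenyl, with its six-membered carbon ring, stays within the scatter of both five-membered sulfur-containing rings at the saturated chain carbon bound to an oxygen on an aromatic ring, as a 1.8-fold lower number from compound 3 to compound 4 (0.27 log units; within the scatter) and a 1.2-fold lower number from compound 2 to compound 4 (0.09 log units; within the scatter) show, so among these compounds a ring sulfur is not required for a number in this range. Among the compounds shown here, the a 2.8-fold lower number from compound 1 to compound 4 (0.45 log units; beyond the scatter) is the largest step so far and, like a 2.3-fold lower number from compound 1 to compound 2 (0.36 log units; beyond the scatter), lies beyond the scatter, although compound 3 goes against this separation of compound 1 with a 1.5-fold lower number from compound 1 to compound 3 (0.19 log units; within the scatter). Nothing available explains these numbers.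

The compounds shown leave open whether an amine, a carboxylic acid or a longer chain would be accepted at this carbon. They also leave open whether plain phenyl or 4-chlorophenyl would read like 4-methylphenyl.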